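The compounds below may be only part of what the source reports. "The series", "measured", "known", "first", "only" and "open" are said of these compounds alone.

In a functional assay on HeLa cells (Homo sapiens) for inhibition, with a stated time of 48 h, tested at 50 uM (on this read-out higher numbers stand for more inhibition of growth at the one concentration tested and lower numbers for less inhibition of growth), three compounds have been measured so far:

Compound 1 (`C=C[C@@](C)(/C=C/c1ccc(O)c([N+](=O)[O-])c1)CCC=C(C)C`) gives 49%
Compound 2 (`COc1ccccc1/C=C/[C@@](C)(/C=C/c1ccc(O)cc1)CCC=C(C)C`) gives 50%
Compound 3 (`COc1ccc(/C=C/[C@@](C)(/C=C/c2ccc(O)cc2)CCC=C(C)C)cc1C=O`) gives 31%

Compound 2 at 50% stands level with compound 1 at 49% within the scatter, while compound 3 at 31% in the same read-out lies below them, beyond the scatter. The next compound, compound 4 (`CC(C)=CCC[C@](C)(/C=C/c1ccc(O)cc1)/C=C/c1ccc(F)cc1`), carries 4-fluorophenyl in place of 2-methoxyphenyl on a double-bonded chain carbon bound to a double-bonded chain carbon. Among the measured compounds shown here, no measured pair shows this change alone. In this assay no step beyond the scatter is therefore expected, only a small estimated downward drift (a number 5 percentage points lower from compound 2 to compound 4 (within the scatter)). Compound 4 is estimated at 45% with an expected range (28% to 62%).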

Compound 4, percent growth inhibition at one concentration: 43%
Compound 4: the middle estimate sits 2 percentage points above what was measured; the range from low to high includes it.
By their numbers in this assay, from the lowest: compound 3; then compounds 4, 1 and 2 (each within the scatter of the next).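

In this assay, among the compounds shown here, the exchange of 2-methoxyphenyl for 4-fluorophenyl on a double-bonded chain carbon bound to a double-bonded chain carbon reads as a number 7 percentage points lower from compound 2 to compound 4 (within the scatter) and is the first step seen at this position. The aryl group here can thus go from one hydrogen-bond acceptor to none with no change beyond the scatter, at least in this pair. Nothing at hand explains this result. Still open, from the compounds shown here alone, is how an amine or a carboxylic acid at this place would read in this assay and whether any group there moves the number beyond the scatter.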